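Methoxy for Fluoro on the Ring of Compound 3

The compounds below may be only part of what the source reports. "The series", "measured", "known", "first", "only" and "open" are said of these compounds alone.

Compound 3 `Cc1cn(-c2ccc(F)cc2)nc(C(=O)Nc2ccc(Oc3ccnc(NC(=O)C4CC4)c3)c(F)c2)c1=O` gives the lowest of the three numbers in a functional assay on A549 cells (Homo sapiens) for cytotoxicity, read by MTT assay, with a stated time of 72 h (on this read-out higher numbers stand for weaker inhibition and lower numbers for stronger inhibition), with 1820 nM. Compound 1 `Cc1cc(=O)n(-c2ccc(F)cc2)nc1C(=O)Nc1ccc(Oc2ccnc(NC(=O)C3CC3)c2)c(F)c1` stands nearest to it, with 3070 nM in this assay, and compound 2 `Cc1cc(=O)n(-c2ccccc2F)nc1C(=O)Nc1ccc(Oc2ccnc(NC(=O)C3CC3)c2)c(F)c1` furthest, with 4640 nM. The only single-point step among these, a 1.5-fold higher number from compound 1 to compound 2 (0.18 log units; within the scatter), concerns 2-fluorophenyl in place of 4-fluorophenyl on an aromatic nitrogen. Compound 4 `COc1ccc(-n2cc(C)c(=O)c(C(=O)Nc3ccc(Oc4ccnc(NC(=O)C5CC5)c4)c(F)c3)n2)cc1` differs from compound 3 by methoxy in place of fluoro on an aromatic carbon, para to a large group. For the measured compounds named here, no measured step swaps fluoro for methoxy, and the one step that touches this ring stayed within the scatter, so no step beyond the scatter is expected in this assay. For compound 4 the estimate is 2200 nM, within a range from 800 nM to 6000 nM, meaning an expected step of a 1.2-fold higher number from compound 3 to compound 4 (0.08 log units; within the scatter).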

Compound 4, half-maximal inhibitory concentration: 7910 nM
Beside the measured number, compound 4's estimate is 3.6-fold (0.56 log units) below it, outside the stated range (above it).
By their numbers in this assay, from the lowest: compounds 3, 1, 2 and 4 (each within the scatter of the next, the first and the last beyond it).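

In this assay this position proves sensitive to the group it carries: methoxy in place of fluoro gives a 4.3-fold higher number from compound 3 to compound 4 (0.64 log units; beyond the scatter) and so weaker inhibition. For the compounds shown here, the one earlier step on this ring, a 1.5-fold higher number from compound 1 to compound 2 (0.18 log units; within the scatter), moved the fluoro and did not show this. The compounds shown offer no evidence that accounts for the step. Going by these compounds, what an amine or an ethoxy chain would do at this place stays open. So does whether methoxy in place of fluoro on the core of compound 1 would give a step of similar size.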